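The source may report more compounds than this note shows. Statements on the series, on what has been measured and on what is new or still open speak of the compounds shown alone.

In a functional assay on MCF7 cells (Homo sapiens) for cytotoxicity, read by ELISA, with a stated time of 4 days (on this read-out lower numbers stand for stronger inhibition and higher numbers for weaker inhibition), compound 1 (`Cc1ccsc1-c1cc(-c2ccco2)cc(-c2ccc(Cl)cc2)n1`) gives 890 nM and compound 2 (`Cc1ccccc1-c1cc(-c2ccoc2)cc(-c2ccc(Cl)s2)n1`) gives 1430 nM so these two values lie within the usual scatter of each other. Compound 3 (`Clc1ccc(-c2cc(-c3ccoc3)cc(-c3cccnc3)n2)s1`) has not yet been measured. It carries pyridin-3-yl in place of the 2-methylphenyl of compound 2 on an aromatic carbon (pyridin-3-yl in place of 2-methylphenyl on an aromatic carbon). Among the measured compounds shown here, no two measured compounds differ in one place only, so no measured step shows how large this change may be. The expected shift in this assay is small and toward weaker inhibition, estimated as a 1.7-fold higher number from compound 2 to compound 3 (0.24 log units; within the scatter) on this read-out. Compound 3 is expected at 2500 nM with an estimated range from 800 nM to 8000 nM in this measurement.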

Compound 3, half-maximal inhibitory concentration: 3480 nM
The estimate for compound 3 lay 1.4-fold (0.14 log units) below the measured number; the measured number falls inside the stated range.
By their numbers in this assay, from the lowest: compounds 1 and 2 (each within the scatter of the next); then compound 3.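

In this assay, placing pyridin-3-yl instead of 2-methylphenyl on the aromatic carbon next to the ring nitrogen gives a 2.4-fold higher number from compound 2 to compound 3 (0.39 log units; beyond the scatter). Among the compounds shown here, this is the first change here made in one place only, and it shows that the number at this position responds to the group it carries, with a modest rise. Nothing available explains this rise. The step swaps a methyl-bearing carbon ring for a nitrogen-containing ring, so it cannot separate losing the methyl from adding the nitrogen. Plain phenyl or pyridin-4-yl at this position could help tell those two apart.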